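Shortening the chain and adding a phenyl on the bicyclic core

The source may report more compounds than this note shows. Statements on the series, on what has been measured and on what is new or still open speak of the compounds shown alone.

Compound 2 `CCC[C@H]1C2CCC(C2)[C@H]1NC1=NCCO1` gives the lowest of the two numbers in a functional assay for agonist activity at Alpha-2C adrenergic receptor (Homo sapiens), read by cAMP accumulation (a lower number here means that less compound is needed, a higher number that more compound is needed for the effect), namely 21.4 nM. Compound 1 `c1ccc(CCC[C@H]2C3CCC(C3)[C@H]2NC2=NCCO2)cc1` gives 60.3 nM in this assay, and a 2.8-fold lower number from compound 1 to compound 2 (0.45 log units; beyond the scatter). Compound 3 `c1ccc(C[C@H]2C3CCC(C3)[C@H]2NC2=NCCO2)cc1` differs from compound 2 by phenyl in place of ethyl on a saturated chain carbon bound to a saturated ring carbon. Among the measured compounds shown here, the only measured step that bears on this also removed a phenyl, though farther along the chain, and it lowered the number modestly; adding a phenyl is therefore expected to raise the number by a small step, a 1.9-fold higher number from compound 2 to compound 3 (0.27 log units; within the scatter). Compound 3 is expected to give about 40 nM in this assay, between 15 nM and 110 nM.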

Compound 3, half-maximal effective concentration: 13.8 nM
Beside the measured number, compound 3's estimate is 2.9-fold (0.46 log units) above it, and the stated range ends above it.
By their numbers in this assay, from the lowest: compounds 3 and 2 (each within the scatter of the next); then compound 1.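

Putting phenyl in place of ethyl on a saturated chain carbon bound to a saturated ring carbon gives a 1.6-fold lower number from compound 2 to compound 3 (0.19 log units; within the scatter) in this assay, so the two compounds cannot be told apart here. Among the compounds shown here, the only earlier step, a 2.8-fold lower number from compound 1 to compound 2 (0.45 log units; beyond the scatter), concerned a phenyl farther along the chain and lay beyond the scatter, whereas at this place the larger group brings no readable change. No measurement shown here explains this difference between the two places. On these data alone, it remains open whether a cyclohexyl in place of the phenyl, or a fluorine or an amine on it, would move the number beyond the scatter.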